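Swapping the Amide Chain on Compound 1: An Expected Outcome

This account rests on a few compounds, and the source may have more. Where it says the series, first, only, none or still open, it means among the compounds named here.

Measured compounds:
compound 1 `CC(C)CCC(=O)Nc1ccn([C@H]2CC[C@H](O[C@H]3O[C@H](C)[C@@H](N(C)C)[C@H](O)[C@H]3O)[C@@H](C)O2)c(=O)n1`: 390 nM
compound 2 `CC(=O)Nc1ccn([C@H]2CC[C@H](O)[C@@H](C)O2)c(=O)n1`: > 20000 nM

Compound 1 `CC(C)CCC(=O)Nc1ccn([C@H]2CC[C@H](O[C@H]3O[C@H](C)[C@@H](N(C)C)[C@H](O)[C@H]3O)[C@@H](C)O2)c(=O)n1` was tested in a functional assay on HCT-116 cells (Homo sapiens) for cytotoxicity, read by sulforhodamine B assay, with a stated time of 24 h; on this read-out lower numbers stand for stronger inhibition and higher numbers for weaker inhibition; in this assay compound 1 gives 390 nM, the only real number among the two results shown. Compound 2 `CC(=O)Nc1ccn([C@H]2CC[C@H](O)[C@@H](C)O2)c(=O)n1` gives in this assay only > 20000 nM, which is a limit of the assay rather than a number; its result sits at the limit of > 20000 nM in this assay, at which 1 of the 2 values shown sits.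

Compound 3 `CCC(C)/C=C/C(=O)Nc1ccn([C@H]2CC[C@H](O[C@H]3O[C@H](C)[C@@H](N(C)C)[C@H](O)[C@H]3O)[C@@H](C)O2)c(=O)n1` has not been measured in this assay. It differs from compound 1 as follows: a group of 6 heavy atoms (6 carbon; no ring) in place of a group of 5 heavy atoms (5 carbon; no ring), on a carbonyl carbon. Within the data shown here, no step between measured compounds that differ in one place is available, so the weight of this change on cytotoxicity can be judged only loosely. Since the chain stays of similar length and carbon-only, the expected step from compound 1 to compound 3 is small, likely within the usual scatter. Compound 3 is estimated at 300 nM, with a range from 100 nM to 1000 nM. This estimate means an expected step of a 1.3-fold lower number from compound 1 to compound 3 (0.11 log units; within the scatter).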

Compound 3, half-maximal inhibitory concentration: 890 nM
For compound 3 the middle estimate is 3.0-fold (0.47 log units) below the measured one, and the stated range covers the measured number.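

In this assay, the group on the carbonyl carbon is shown for the first time to matter: putting the unbranched-name-free chain of 6 carbon atoms with its double bond in place of isopentyl gives a 2.3-fold higher number from compound 1 to compound 3 (0.36 log units; beyond the scatter), a modest step that lies beyond the scatter. The position therefore accepts this change without a collapse, since compound 3 still gives a real number, 890 nM, and not a limit. Nothing among the results shown explains the step.

The compounds shown do not separate the double bond from the change in carbon count, so either could carry the step. Going by these compounds, how a longer chain, a phenyl ring or a terminal amine would read on the carbonyl carbon in this assay also stays open.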